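The compounds below may be only part of what the source reports. "The series", "measured", "known", "first", "only" and "open" are said of these compounds alone.

Measured so far in an assay on HEK293 cells for inhibition of sodium-dependent dopamine transporter (Homo sapiens), read by scintillation counting; on this read-out higher numbers stand for weaker inhibition and lower numbers for stronger inhibition:
compound 1, `O=[N+]([O-])c1ccc(-c2nnnn2CCN2CCC(Cc3ccccc3)CC2)cc1`, gives 1980 nM
compound 2, `FC(F)(F)c1cccc(-c2nnnn2CCCN2CCC(Cc3ccccc3)CC2)c1`, gives 3740 nM

The number for compound 2 and the number for compound 1 lie within the usual scatter of repeated measurements of each other, so neither compound stands apart from the other. Compound 3, `Clc1ccccc1-c1nnnn1CCCN1CCC(Cc2ccccc2)CC1`, differs from compound 2 in one place: 2-chlorophenyl in place of 3-(trifluoromethyl)phenyl on an aromatic carbon. Within the data shown here, no measured pair shows what such an exchange does, so there is no basis for a direction. The expected step is a 1.2-fold lower number from compound 2 to compound 3 (0.10 log units; within the scatter), nothing beyond the scatter. Compound 3 is therefore estimated at 3000 nM, with a range from 800 nM to 12000 nM.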

Compound 3, half-maximal inhibitory concentration: 6550 nM
The estimate for compound 3 lay 2.2-fold (0.34 log units) below the measured number, and the stated range covers the measured number.
By their numbers in this assay, from the lowest: compounds 1, 2 and 3 (each within the scatter of the next, the first and the last beyond it).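

In this assay, putting 2-chlorophenyl in place of 3-(trifluoromethyl)phenyl on this aromatic carbon gives a 1.8-fold higher number from compound 2 to compound 3 (0.24 log units; within the scatter). This first measured exchange at the position therefore does not separate the two substituted phenyl groups. No outside evidence bears on this result. As far as these compounds go, what a group of another kind, such as an amine or a carboxylic acid, would do on this carbon stays open, as does the effect of a longer chain on the ring nitrogen with all else held the same.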